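Compound 4 and the Shift from Thiophene to Acetylphenyl

This account rests on a few compounds, and the source may have more. Where it says the series, first, only, none or still open, it means among the compounds named here.

Of the compounds shown here, three sharing one core have been measured in a functional assay on OVCAR-8 cells (Homo sapiens) for inhibition, read by sulforhodamine B assay, with a stated time of 48 h, tested at 10 uM; a lower number here means less inhibition, a higher number more inhibition at the concentration tested (going by the name of the read-out). Compound 1 `COc1ccc(-c2cn3ccnc3c(-c3ccc4ncn(C5CCCCC5)c4c3)n2)cc1` gives 71.2%, compound 2 `Fc1ccc(-c2cn3ccnc3c(-c3ccc4ncn(C5CCCCC5)c4c3)n2)cc1` gives 9.54%, and compound 3 `c1cn2cc(-c3ccsc3)nc(-c3ccc4ncn(C5CCCCC5)c4c3)c2n1` gives 12.1%. Compound 3 thus stands second highest of the three, near compound 2 and far below compound 1: the step of a number 59.1 percentage points lower from compound 1 to compound 3 (beyond the scatter) was large, while a number 2.6 percentage points higher from compound 2 to compound 3 (within the scatter) was within the scatter. Compound 4 `CC(=O)c1ccc(-c2cn3ccnc3c(-c3ccc4ncn(C5CCCCC5)c4c3)n2)cc1` carries the change (4-acetylphenyl in place of thiophen-3-yl on an aromatic carbon). Both measured steps concern this same position, and each replacement of the 4-methoxyphenyl lowered the read-out sharply, so a return toward the level of compound 1 cannot be assumed. The expected step of a number 22.9 percentage points higher from compound 3 to compound 4 (beyond the scatter) is therefore modest, with wide uncertainty. Compound 4 is estimated at 35%, expected to fall between 5% and 75%.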

Compound 4, a percentage reported as inhibition, at one concentration (the size of the read-out at that concentration, not a potency): 6.38%
Compound 4: middle estimate off by 28.6 percentage points, on the high side; low and high end bracket the measured number.
By their numbers in this assay, from the lowest: compounds 4, 2 and 3 (each within the scatter of the next); then compound 1.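

In this assay the 4-acetylphenyl group brings no return toward compound 1, the step being a number 64.8 percentage points lower from compound 1 to compound 4 (beyond the scatter) and thus large. Against the other replacements the read-out stays level, with a number 5.7 percentage points lower from compound 3 to compound 4 (within the scatter) and a number 3.2 percentage points lower from compound 2 to compound 4 (within the scatter) in turn. Among the four groups at this position, only the 4-methoxyphenyl of compound 1 therefore stands apart, and no evidence at hand bears on this result. The compounds shown leave open whether an ethoxy or a dimethylamino group in place of the methoxy would hold the read-out near that of compound 1.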